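Sulfonamide chain change from compound 2 to compound 3

The source may report more compounds than this note shows. Statements on the series, on what has been measured and on what is new or still open speak of the compounds shown alone.

Measured in a functional assay on cells (Panel leukemia (Carcinoma cell lines), Homo sapiens) for inhibition, read by sulforhodamine B assay, with a stated time of 48 h (on this read-out higher numbers stand for weaker inhibition and lower numbers for stronger inhibition), so far
- Compound 1 `CN1CCCN(CCNc2nccc(-c3c(-c4cccc(O)c4)nc4sccn34)n2)S1(=O)=O` gives 11900 nM
- Compound 2 `O=S(=O)(NCCCNc1nccc(-c2c(-c3cccc(O)c3)nc3sccn23)n1)c1cccc(F)c1` gives 2040 nM

Of these two compounds, compound 2 stands lowest at 2040 nM and so shows the stronger inhibition. The next compound to be tested is compound 3 `O=S(=O)(NCCNc1nccc(-c2c(-c3cccc(O)c3)nc3sccn23)n1)c1ccc(F)cc1` and it differs from compound 2 in one place: ((4-fluorophenyl)sulfonyl)amino in place of (((3-fluorophenyl)sulfonyl)amino)methyl on a saturated chain carbon, two bonds along the chain from a nitrogen on an aromatic ring. In words, ((4-fluorophenyl)sulfonyl)amino stands in place of (((3-fluorophenyl)sulfonyl)amino)methyl on a saturated chain carbon, two bonds along the chain from a nitrogen on an aromatic ring. Among the measured compounds shown here, only one measured step bears on this change, and only loosely: a 5.8-fold lower number from compound 1 to compound 2 (0.77 log units; beyond the scatter). That step exchanged a non-aromatic ring for a fluorinated aromatic one, whereas compound 3 keeps an aromatic ring of that kind. No measurement isolates the present change, so a small step is expected, probably not beyond the scatter and leaning towards a higher number. The estimated step is a 1.4-fold higher number from compound 2 to compound 3 (0.14 log units; within the scatter) in this assay on this reasoning. Compound 3 is estimated at 2800 nM with an expected range of 1000 nM to 8000 nM in this assay here.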

Compound 3, half-maximal inhibitory concentration: 2820 nM
Compound 3: middle estimate off by 1.0-fold (0.00 log units), on the low side; the range from low to high includes it.
By their numbers in this assay, from the lowest: compounds 2 and 3 (each within the scatter of the next); then compound 1.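

In this assay there is a 1.4-fold higher number from compound 2 to compound 3 (0.14 log units; within the scatter), so ((4-fluorophenyl)sulfonyl)amino in place of (((3-fluorophenyl)sulfonyl)amino)methyl on this saturated chain carbon leaves the read-out within the scatter, something the earlier pair could not show. The comparison with the non-aromatic ring group also holds for the shorter group, with a 4.2-fold lower number from compound 1 to compound 3 (0.63 log units; beyond the scatter), so in these three compounds both fluorophenyl sulfonyl groups give lower numbers than the ring group of compound 1, and the step stays beyond the scatter with either of them. Nothing available explains why these numbers fall as they do.

As far as these compounds go, the step from compound 2 to compound 3 alters the chain and the place of the fluorine together, so it remains open whether each change alone would leave the number unmoved or whether the two offset each other. Also open, from the compounds shown here alone, is how the number would respond to a phenyl ring carrying no fluorine, a longer chain, or a carboxamide in place of the sulfonyl amino group.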